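From 2,4-dichlorophenyl to 2-chloro-4-fluorophenyl

A few compounds are considered here, and "the series" means these few. Any claim that something is new, unique, unknown or untested is made for them only; others in the source may bear on it.

In a functional assay on MCF7 cells (Homo sapiens) (on this read-out lower numbers stand for stronger inhibition of growth and higher numbers for weaker inhibition of growth), compound 1 `O=S(=O)(/C=C/c1ccccc1)Cc1ccc(Nc2ncnc3ccccc23)cc1` gives 74000 nM and compound 2 `O=S(=O)(/C=C/c1ccc(Cl)cc1Cl)Cc1ccc(Nc2ncnc3ccccc23)cc1` gives 4000 nM while compound 3 `O=S(=O)(/C=C/c1ccc(Cl)cc1Cl)Cc1ccc(Nc2ncnc3cc(Cl)ccc23)cc1` gives 25000 nM as its reading. That places compound 3 second highest of the three numbers, between the other two.

Compound 4 `O=S(=O)(/C=C/c1ccc(F)cc1Cl)Cc1ccc(Nc2ncnc3cc(Cl)ccc23)cc1` has not been measured yet. It differs from compound 3 in one place only: fluoro in place of chloro on an aromatic carbon is the whole change. The swap sits para to a large group and meta to a chloro group, so 2,4-dichlorophenyl becomes 2-chloro-4-fluorophenyl.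

The closest measured step is a 19-fold lower number from compound 1 to compound 2 (1.27 log units; beyond the scatter) and it is large. It came with 2,4-dichlorophenyl in place of phenyl, the same group that changes now. The other step, a 6.3-fold higher number from compound 2 to compound 3 (0.80 log units; beyond the scatter) in size and modest, came with chloro in place of hydrogen elsewhere in the molecule. Within the data shown here, no measured pair swaps chloro for fluoro, and here one chloro stays while the other is replaced rather than removed. A small upward move at most is therefore expected, and the estimated step in this assay is a 1.2-fold higher number from compound 3 to compound 4 (0.08 log units; within the scatter) with nothing beyond the scatter foreseen. The estimate for compound 4 is 30000 nM with an expected range from 11000 nM to 80000 nM around it.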

Compound 4, concentration for 50% growth inhibition: 15000 nM
Compound 4: the middle estimate sits 2.0-fold (0.30 log units) above what was measured; the range from low to high includes it.
By their numbers in this assay, from the lowest: compound 2; then compounds 4 and 3 (each within the scatter of the next); then compound 1.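

In this assay, putting fluoro in place of chloro on this aromatic carbon, para to a large group and meta to a chloro group, gives a 1.7-fold lower number from compound 3 to compound 4 (0.22 log units; within the scatter), so this read-out does not separate compound 3 from compound 4. The earlier step on this ring, a 19-fold lower number from compound 1 to compound 2 (1.27 log units; beyond the scatter), brought in both chloro groups at once and could not show whether the one at this position had to be chloro; the new pair shows that, at least on the chlorinated core of compound 3, fluoro serves here about as well. This is a finding about one swap on one background, and nothing available here explains the reading at the level of cause.

The compounds shown leave open how this position would respond to a group of another kind, such as a methoxy group, an amine or a carboxylic acid, in place of the fluoro. They also leave open whether the same swap would read alike on compound 2, whose core has no added chloro, and what the remaining chloro of the 2-chloro-4-fluorophenyl group contributes on its own.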